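Carboxyphenyl positional swap on the shared core

A few compounds are considered here, and "the series" means these few. Any claim that something is new, unique, unknown or untested is made for them only; others in the source may bear on it.

Measured so far in a functional assay on HEK293 cells for agonist activity at Bile acid receptor (Homo sapiens), read by a luciferase reporter; on this read-out lower numbers stand for smaller maximal responses and higher numbers for larger maximal responses:
compound 1 `CN(Cc1cccc(C(=O)O)c1)c1ccc(OCc2c(-c3c(Cl)cccc3Cl)noc2C2CC2)nc1C(F)(F)F` gives 43%
compound 2 `CC(Nc1ccc(C(=O)O)cc1)c1ccc(OCc2c(-c3c(Cl)cccc3Cl)noc2C2CC2)nc1C(F)(F)F` gives 49%
compound 3 `O=C(O)c1ccccc1OCc1ccc(OCc2c(-c3c(Cl)cccc3Cl)noc2C2CC2)nc1C(F)(F)F` gives 33%

Compound 3 sits lowest of the three numbers in this assay, though its gap to compound 1 is within the scatter; only its gap to compound 2 is beyond it. The measured steps all alter the linker that carries the carboxyphenyl group: a number 6 percentage points higher from compound 1 to compound 2 (within the scatter), a number 10 percentage points lower from compound 1 to compound 3 (within the scatter), and a number 16 percentage points lower from compound 2 to compound 3 (beyond the scatter). Going by the values given here, none of them keeps the (carboxyphenoxy)methyl linker and moves the acid alone, so no measured step bears directly on the present change.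

Compound 4 `O=C(O)c1cccc(OCc2ccc(OCc3c(-c4c(Cl)cccc4Cl)noc3C3CC3)nc2C(F)(F)F)c1` differs from compound 3 only in 3-carboxyphenyl in place of 2-carboxyphenyl on an oxygen on a saturated carbon. With the same atoms joined differently and the linker untouched, the step is expected to stay small, likely within the scatter and without a clear direction, so a number 3 percentage points higher from compound 3 to compound 4 (within the scatter) is the estimate. For compound 4 the maximal response in this assay is expected to be 36%, in the range 24% to 52%.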

Compound 4, largest response reached (reported as efficacy), in percent of the reference or control that the assay uses: 41%
The estimate for compound 4 lay 5 percentage points below the measured number, within the range that was stated.
By their numbers in this assay, from the lowest: compounds 3, 4, 1 and 2 (each within the scatter of the next, the first and the last beyond it).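

In this assay, going by these compounds alone, the one step that keeps the linker and changes only the acid's place gives a number 8 percentage points higher from compound 3 to compound 4 (within the scatter), so at this position, on an oxygen on a saturated carbon, 2-carboxyphenyl and 3-carboxyphenyl are not told apart. With 3-carboxyphenyl the linker comparisons also stay inside the scatter, as a number 8 percentage points lower from compound 2 to compound 4 (within the scatter) and a number 2 percentage points lower from compound 1 to compound 4 (within the scatter) show, whereas a number 16 percentage points lower from compound 2 to compound 3 (beyond the scatter) lay beyond it, so that single larger gap does not extend to the (3-carboxyphenoxy)methyl linker. No measured information accounts for any of these steps. Still open, on these data alone, is how 4-carboxyphenyl on the same oxygen would read against these two isomers. Also open, as far as these compounds go, is whether a carboxamide in place of the carboxylic acid would keep the maximal response on this linker.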